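Swapping a saturated ring for a carboxyphenyl on the ketone

The compounds below may be only part of what the source reports. "The series", "measured", "known", "first", "only" and "open" are said of these compounds alone.

Of the compounds shown here, three have been measured so far in a functional assay on DU-145 cells (Homo sapiens) for inhibition, read by trypan blue exclusion, with a stated time of 96 h; a higher number here means a weaker inhibitor of growth, a lower number a stronger inhibitor of growth. Compound 1 `Cc1ccc(CS(=O)(=O)/C(=C/c2c[nH]c3ccc(Br)cc23)C(=O)c2ccc(Cl)cc2)cc1` gives 10000 nM there. Compound 2 `O=C(/C(=C\c1ccc([N+](=O)[O-])c(O)c1)SCc1ccc(Br)cc1)C1CCNC1` gives only a limit of the assay in this assay, > 100000 nM, so its true value is not known as a number. Compound 3 `Cc1ccc(S/C(=C/c2ccc(N(C)C)cc2)C(=O)c2ccc(Cl)cc2)cc1` likewise gives only a limit in this assay, > 100000 nM. Thus compound 2 stands at the weak end of what has been seen: the limit of > 100000 nM in this assay, at which 2 of the 3 values shown sit, and compound 1 alone gives a measured number.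

The next compound, compound 4 `O=C(O)c1ccc(C(=O)/C(=C\c2ccc([N+](=O)[O-])c(O)c2)SCc2ccc(Br)cc2)cc1`, keeps the core of compound 2 and changes a single place. The change is 4-carboxyphenyl in place of pyrrolidin-3-yl on a carbonyl carbon. Going by the values given here, no two measured compounds differ in just one place, so no measured step can guide the size of this one. Compound 1 and compound 3 each carry an aromatic ring on the carbonyl carbon, yet their values in this assay lie far apart, so an aromatic ring there is no guarantee of a number.

Compound 4 is expected to remain a weak inhibitor of growth, with an estimate of 80000 nM and a range from 20000 nM to 200000 nM. The step expected is an at least 1.2-fold lower number from compound 2 to compound 4 (0.09 log units; that floor lies within the scatter), and a limit rather than a number is quite possible.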

Compound 4, concentration for 50% growth inhibition: 10000 nM
For compound 4 the middle estimate is 8.0-fold (0.90 log units) above the measured one; measured number outside the range, below it.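

Going by these compounds alone, this is the first pair of compounds that differ in one place only, so the group on the carbonyl carbon can now be judged directly: in this assay, 4-carboxyphenyl in place of pyrrolidin-3-yl gives an at least 10-fold lower number from compound 2 to compound 4 (1.00 log units; beyond the scatter). With the rest of the structure held fixed, this one position is thus shown to matter for growth inhibition, and compound 4 gives 10000 nM. As far as these compounds go, the true size of the step remains unknown, since compound 2 has only a limit of the assay and not a number: the limit of > 100000 nM in this assay, at which 2 of the 4 values shown sit.

A single pair cannot tell whether the gain comes from the aromatic ring of the entering group or from the carboxylic acid it carries, as the two arrive together in this change. A plain phenyl, a methyl ester or a primary amide on the same carbonyl carbon would pull these two apart, and would show whether the acid itself is needed for a measured value in this series.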